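A Larger Amine Chain on a Flat Series

The compounds below may be only part of what the source reports. "The series", "measured", "known", "first", "only" and "open" are said of these compounds alone.

In a functional assay on PC-3 cells (Homo sapiens) for antiproliferative activity, read by WST assay, with a stated time of 3 days (a higher number here means a weaker inhibitor, a lower number a stronger inhibitor), compound 1 `CCCCCOc1c(-c2cc(OC)c(OC)c(OC)c2)oc2ccccc2c1=O` gives 22200 nM, compound 2 `COc1cc(-c2oc3ccccc3c(=O)c2OC(C)C)cc(OC)c1OC` gives 21200 nM and compound 3 `CCN(CC)CCCOc1c(-c2cc(OC)c(OC)c(OC)c2)oc2ccccc2c1=O` gives 13600 nM. Compound 3 cannot be ranked against the other two: the measured steps, a 1.6-fold lower number from compound 1 to compound 3 (0.21 log units; within the scatter) and a 1.6-fold lower number from compound 2 to compound 3 (0.19 log units; within the scatter), are small, as is a 1.0-fold lower number from compound 1 to compound 2 (0.02 log units; within the scatter). Compound 4 `CCCN(CCC)CCCCOc1c(-c2cc(OC)c(OC)c(OC)c2)oc2ccccc2c1=O` brings one change, ((dipropylamino)methyl in place of diethylamino on a saturated chain carbon, three bonds along the chain from an oxygen on an aromatic ring), which also reads as 3-(diethylamino)propyl to 4-(dipropylamino)butyl. Among the measured compounds shown here, no measured step alters the amine itself, but the whole group on that oxygen has changed with little effect on the number. No step beyond the scatter is therefore expected, and the estimate is a 1.2-fold lower number from compound 3 to compound 4 (0.09 log units; within the scatter). The expected value for compound 4 is 11000 nM, within a range of 4000 nM to 25000 nM.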

Compound 4, half-maximal inhibitory concentration: 11600 nM
Beside the measured number, compound 4's estimate is 1.1-fold (0.02 log units) below it; measured number inside the range.
By their numbers in this assay, from the lowest: compounds 4, 3, 2 and 1 (each within the scatter of the next).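

Swapping diethylamino for (dipropylamino)methyl alters the amine itself for the first time, and in this assay the step is a 1.2-fold lower number from compound 3 to compound 4 (0.07 log units; within the scatter). Against the chains without nitrogen, 4-(dipropylamino)butyl in place of isopropyl gives a 1.8-fold lower number from compound 2 to compound 4 (0.26 log units; within the scatter), and dipropylamino in place of methyl, four bonds along the chain from that oxygen, gives a 1.9-fold lower number from compound 1 to compound 4 (0.28 log units; within the scatter), so even the largest group shown on this oxygen stays within the scatter. Nothing available explains this flat result. As far as these compounds go, whether an amine held in a ring, such as piperidine or morpholine, or a carboxylic acid at the end of the chain would step beyond the scatter stays open.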